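The compounds below may be only part of what the source reports. "The series", "measured", "known", "first", "only" and "open" are said of these compounds alone.

Working notes on the series in a functional assay for inhibition, with Homo sapiens as the target (on this read-out lower numbers stand for stronger inhibition and higher numbers for weaker inhibition), covering compound 1 `O=C(O)CCCCCn1nc(-c2ccccc2)c(-c2ccccc2)c1-c1ccccc1`, compound 2 `O=C(O)C[S+]([O-])CCCCCCn1nc(-c2ccccc2)c(-c2ccccc2)c1-c1ccccc1` and compound 3 `NC(=O)CCCCCCCCn1nc(-c2ccccc2)c(-c2ccccc2)c1-c1ccccc1`. Compound 1 gives > 78000 nM, which is a limit of the assay. Of the two actual numbers, the higher belongs to compound 3 at 33000 nM, while compound 2 stands at 6500 nM.

Compound 4 `c1ccc(-c2nn(CCCCCCCCc3nnn[nH]3)c(-c3ccccc3)c2-c2ccccc2)cc1` is still unmeasured. The change is 1H-tetrazol-5-yl in place of carbamoyl on a saturated chain carbon, eight bonds along the chain from an aromatic nitrogen.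

Within the data shown here, no measured step isolates this exchange. The closest is a 5.1-fold higher number from compound 2 to compound 3 (0.71 log units; beyond the scatter), but it alters the chain as well as the end group. The other two steps, an at least 12-fold lower number from compound 1 to compound 2 (1.07 log units; beyond the scatter) and an at least 2.3-fold lower number from compound 1 to compound 3 (0.37 log units; beyond the scatter), both start from a limit. Compound 1 also carries a carboxy end without a low number, which goes against reading compound 2 as a general rule for that end group.

On the strength of compound 2 at 6500 nM, a modest move to a lower number is expected in this assay, with little confidence. The expected step is a 2.2-fold lower number from compound 3 to compound 4 (0.34 log units; beyond the scatter). For compound 4 the estimate is 15000 nM, with an expected range of 3000 nM to 60000 nM.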

Compound 4, half-maximal inhibitory concentration: 1040 nM
Estimate against measurement, compound 4: 14-fold (1.16 log units) above; the measured number lies below the stated range.
By their numbers in this assay, from the lowest: compound 4; then compound 2; then compound 3. At a limit, above all of these: compound 1.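

In this assay, 1H-tetrazol-5-yl in place of carbamoyl on a saturated chain carbon, eight bonds along the chain from an aromatic nitrogen, gives a 32-fold lower number from compound 3 to compound 4 (1.50 log units; beyond the scatter) and is the only step shown that changes the end group alone. Compound 4 also gives a 6.3-fold lower number from compound 2 to compound 4 (0.80 log units; beyond the scatter) in a comparison that alters the chain as well as the end group, so this step says less about 1H-tetrazol-5-yl itself. The step with an at least 75-fold lower number from compound 1 to compound 4 (1.87 log units; beyond the scatter) starts from a limit of compound 1 and fixes only a bound: the limit of > 78000 nM in this assay, at which 1 of the 4 values shown sits.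

From the compounds shown here alone, whether a carboxylic acid on the same chain as compound 4 would match 1H-tetrazol-5-yl stays open, since compound 1 and compound 2 carry their acid ends on other chains. Going by these compounds, how a shorter or longer chain bearing 1H-tetrazol-5-yl would read in this assay also stays open.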